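The compounds below may be only part of what the source reports. "The series", "measured", "known", "first", "only" and "open" are said of these compounds alone.

Three compounds share one core and differ only in the group attached to a nitrogen on the aromatic ring. Among the compounds with values here, compound 1 `O[C@@H]1[C@H](O)[C@@H]2C[C@@H]2[C@H]1n1cnc2c(NC3CCC3)nc(Cl)nc21` carries a cyclobutyl there, and in an assay on CHO cells for displacement of a labelled ligand from adenosine receptor A1 (Homo sapiens), read by scintillation counting, with a stated time of 60 min (a lower number here means a stronger inhibitor, a higher number a weaker inhibitor), compound 1 gives 51.6 nM, the lowest of the two numbers measured so far. Compound 2 `CCC(CC)Nc1nc(Cl)nc2c1ncn2[C@H]1[C@H](O)[C@H](O)[C@@H]2C[C@@H]21` carries a pentan-3-yl instead, and in this assay compound 2 gives 78.8 nM. Within the data shown here, the one measured step, a 1.5-fold higher number from compound 1 to compound 2 (0.18 log units; within the scatter), shows that swapping one small saturated group for another leaves the result essentially unchanged.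

Compound 3 `O[C@@H]1[C@H](O)[C@@H]2C[C@@H]2[C@H]1n1cnc2c(NCc3cc(F)ccc3F)nc(Cl)nc21` has not yet been measured. Compared with compound 1 it differs as follows: 2,5-difluorobenzyl in place of cyclobutyl on a nitrogen on an aromatic ring. Among the measured compounds shown here, the measured step bears on it only loosely, since a 2,5-difluorobenzyl is a larger and flatter group than either a cyclobutyl or a pentan-3-yl, and no measured compound here carries an aromatic group at that position. For the measured compounds named here, with the one step within the scatter, the expectation is a modest weakening at most; the estimate is a 2.3-fold higher number from compound 1 to compound 3 (0.37 log units; beyond the scatter). Compound 3 is therefore expected to give about 120 nM, somewhere between 35 nM and 450 nM.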

Compound 3, inhibition constant: 1260 nM
Beside the measured number, compound 3's estimate is 11-fold (1.02 log units) below it, and the stated range ends below it.
By their numbers in this assay, from the lowest: compounds 1 and 2 (each within the scatter of the next); then compound 3.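

The nitrogen on the aromatic ring proves far less tolerant than the first two compounds suggested: in this assay, 2,5-difluorobenzyl in place of cyclobutyl gives a 24-fold higher number from compound 1 to compound 3 (1.39 log units; beyond the scatter), and in place of pentan-3-yl it gives a 16-fold higher number from compound 2 to compound 3 (1.20 log units; beyond the scatter). Both steps are large, whereas the step between the two saturated groups stayed within the scatter, so among these three compounds, exchanging one saturated group for the other matters little, while moving to a group of 9 heavy atoms with a six-membered aromatic ring and two fluorines matters a great deal. No measurement here shows which feature of the entering group accounts for the weaker result.

Going by these compounds, it remains open whether a plain benzyl with no fluorine, or a saturated cyclohexyl, would give a number close to that of compound 1 or close to that of compound 3, which would help separate the effect of the aromatic ring from that of the fluorines and of the group's overall bulk. Also open, on these data alone, is how a phenyl placed directly on the nitrogen, without the single carbon link of a benzyl, would compare.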